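Cytotoxicity Stays at the Assay Limit Across Three Analogues

The source may hold more compounds than are shown below. What is called first, only, known or untested is meant among the compounds shown, and "the series" means these compounds.

Measured compounds:
- compound 1, `CC(C)(C)C#Cc1cc(N(C(=O)[C@H]2CC[C@H](C)CC2)[C@H]2CC[C@](O)(CO[C@H]3CCOC3)CC2)c(C(=O)O)s1`, > 20000 nM
- compound 2, `CC(C)(C)C#Cc1cc(N(C(=O)[C@H]2CC[C@H](C)CC2)[C@H]2C[C@@H](Oc3cccnc3)C2)c(C(=O)O)s1`, > 20000 nM
- compound 3, `C[C@@H](CCOc1cccnc1)N(c1cc(C#CC(C)(C)C)sc1C(=O)O)C(=O)[C@H]1CC[C@H](C)CC1`, > 20000 nM

In an ADME assay on MT4 cells (Homo sapiens) for cytotoxicity, with a stated time of 5 days (a lower number here means that less compound is tolerated, a higher number that more compound is tolerated), compound 1 gives > 20000 nM, which is a limit of the assay and not a number. Compound 2 likewise reaches only a limit, > 20000 nM. Compound 3 stands at the same limit, > 20000 nM, so its place among the three cannot be ranked. For the measured compounds named here, the one step between measured compounds, a step that the two limits leave unreadable from compound 2 to compound 3, is unreadable for the same reason.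

Compound 4, `CC(C)(C)C#Cc1cc(N(C(=O)[C@H]2CC[C@H](C)CC2)[C@H]2CC[C@H](O)CC2)c(C(=O)O)s1`, is not yet measured in this assay. It differs from compound 3 by 4-hydroxycyclohexyl in place of 1-methyl-3-((pyridin-3-yl)oxy)propyl on an amide-type nitrogen. No measured step can be read in size, but the limit is shared by every compound shown, as the limit of > 20000 nM in this assay, at which 3 of the 3 values shown sit, states. The step of a number no higher from compound 3 to compound 4 (the limit leaves the size open) is therefore expected to be none beyond the scatter, with the limit most likely reported again. For compound 4 the estimate is 20000 nM, within a range from 10000 nM to 40000 nM.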

Compound 4, half-maximal cytotoxic concentration: > 20000 nM
Compound 4 was reported as a limit; the forecaster's own chance of this, stated with the estimate: 85%; the middle value sits exactly at the limit.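

In this assay compound 4 gives > 20000 nM as a limit of the assay and not a number, so its steps from compound 1, compound 2 and compound 3 cannot be read. The compounds shown leave open at what concentration any of them becomes cytotoxic, since all share one reading: the limit of > 20000 nM in this assay, at which 4 of the 4 values shown sit.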